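This account rests on a few compounds, and the source may have more. Where it says the series, first, only, none or still open, it means among the compounds named here.

In a functional assay on HeLa cells (Homo sapiens) for inhibition (a lower number here means a stronger inhibitor, a higher number a weaker inhibitor), compound 2 `O=C1O/C(=C\Cn2cc(Cl)c(=O)[nH]c2=O)C(OCc2ccccc2)=C1OCc1ccccc1` gives 30000 nM, and compound 1 `O=C1O/C(=C\Cn2cc(I)c(=O)[nH]c2=O)C(OCc2ccccc2)=C1OCc1ccccc1` gives 40000 nM. For the measured compounds named here, these two numbers lie within the usual scatter of each other, so compound 2 stands level with the only other measured compound. Compound 3 `O=C1O/C(=C\Cn2cc(Br)c(=O)[nH]c2=O)C(OCc2ccccc2)=C1OCc1ccccc1` has a single change from compound 2: bromo in place of chloro on an aromatic carbon. In words, this is bromo in place of chloro on an aromatic carbon. Going by the values given here, only one measured step bears on it, a swap of chloro in place of iodo at the same aromatic carbon, which gave a 1.3-fold lower number from compound 1 to compound 2 (0.12 log units; within the scatter). Among the compounds with values here, with that step as the only guide, no shift beyond the scatter is expected in this assay. The expected result is a 1.1-fold higher number from compound 2 to compound 3 (0.05 log units; within the scatter). The estimate for compound 3 is 34000 nM, with an expected range from 17000 nM to 65000 nM.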

Compound 3, half-maximal inhibitory concentration: 30000 nM
The estimate for compound 3 lay 1.1-fold (0.05 log units) above the measured number; low and high end bracket the measured number.
By their numbers in this assay, from the lowest: compounds 2, 3 and 1 (each within the scatter of the next).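

With bromo in place, three halogens have now been compared at this aromatic carbon in this assay, and the new swaps give (no change at the digits printed from compound 2 to compound 3 (within the scatter)) and (a 1.3-fold lower number from compound 1 to compound 3 (0.12 log units; within the scatter)). Together with the earlier step, this means that no exchange among chloro, bromo and iodo at this position moves the number beyond the scatter, so the three compounds stand level. Nothing available here says why these three halogens read alike.

Still open, as far as these compounds go, is whether this level result extends beyond these three groups, since a fluoro, a methyl, an amine or a nitrile at the same carbon could read differently. From the compounds shown here alone, it also remains open whether any replacement at this position can give a clearly lower number than these three compounds share.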